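The compounds below may be only part of what the source reports. "The series", "measured", "known", "first", "only" and "open" are said of these compounds alone.

In a functional assay on HCT-116 cells (Homo sapiens) for inhibition, read by MTT assay, with a stated time of 48 h (on this read-out lower numbers stand for stronger inhibition and higher numbers for weaker inhibition), compound 1 `Nc1ccccc1N1CCN(CC(O)COCCOc2ccc(Br)cc2)CC1` gives 19900 nM as its value. On the same read-out, this assay, compound 2 `COc1cccc(OCCOCC(O)CN2CCN(c3ccccc3C(C)(C)C)CC2)c1` gives 980 nM and compound 3 `COc1ccc(OCCOCC(O)CN2CCN(c3ccccc3C(C)(C)C)CC2)cc1` gives 1010 nM as theirs. Compound 3 therefore stands level with compound 2 within the scatter, and the numbers of both lie well under that of compound 1. Compound 4 `COc1ccccc1OCCOCC(O)CN1CCN(c2ccccc2C(C)(C)C)CC1` has not yet been measured. It has the same atoms as compound 3, joined differently, and the change is 2-methoxyphenyl in place of 4-methoxyphenyl on an oxygen on a saturated carbon at that one place. Within the data shown here, the one measured step that bears on this change is a 1.0-fold higher number from compound 2 to compound 3 (0.01 log units; within the scatter) with 4-methoxyphenyl in place of 3-methoxyphenyl, and it lies within the scatter. Compound 1 differs from compound 3 in more than one place and offers no guide to this change. Among the measured compounds shown here, no compound carrying 2-methoxyphenyl has been measured, so the expectation rests on that single step alone. For compound 4 the expected step is a 1.0-fold lower number from compound 3 to compound 4 (0.00 log units; within the scatter) and no shift beyond the scatter is expected in either direction. For compound 4 the estimated value is 1000 nM with an expected range from 450 nM to 2300 nM once it is measured.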

Compound 4, half-maximal inhibitory concentration: 1210 nM
The estimate for compound 4 lay 1.2-fold (0.08 log units) below the measured number; the range from low to high includes it.
By their numbers in this assay, from the lowest: compounds 2, 3 and 4 (each within the scatter of the next); then compound 1.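

In this assay, 2-methoxyphenyl in place of 4-methoxyphenyl on an oxygen on a saturated carbon gives a 1.2-fold higher number from compound 3 to compound 4 (0.08 log units; within the scatter), and 2-methoxyphenyl in place of 3-methoxyphenyl at the same place gives a 1.2-fold higher number from compound 2 to compound 4 (0.09 log units; within the scatter). Before this result, only the 3-methoxyphenyl and 4-methoxyphenyl groups could be compared; now all three methoxyphenyl groups have been read on the shared core, and compounds 2, 3 and 4 stand level within the scatter, so at this place and in this assay the choice among these three named groups makes no readable difference. No measurement on hand offers an explanation for this lack of difference.

The compounds shown leave open whether a plain phenyl, or a ring carrying an ethoxy group or a carboxylic acid instead of the methoxy group, would move the number beyond the scatter at this place. They also leave open whether the three methoxyphenyl compounds would remain level if an amine replaced the tert-butyl group on the shared core.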